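This account rests on a few compounds, and the source may have more. Where it says the series, first, only, none or still open, it means among the compounds named here.

The compounds were compared in a functional assay on HepG2 cells (Homo sapiens) for cytotoxicity, read by MTT assay, with a stated time of 72 h; a higher number here means a weaker inhibitor, a lower number a stronger inhibitor. Compound 1 `CNC(=O)c1cc(Oc2ccc(NC(=O)c3nn(-c4ccccc4OC(F)(F)F)c(=O)cc3C)cc2F)ccn1` returns only a limit of the assay there, > 40000 nM. Compound 2 `CNC(=O)c1cc(Oc2ccc(NC(=O)c3nn(-c4cccc(F)c4)c(=O)cc3C)cc2F)ccn1` gives 10200 nM in this assay. Among the compounds with values here, the one change between these two is 3-fluorophenyl in place of 2-(trifluoromethoxy)phenyl on an aromatic nitrogen, and it brought an at least 3.9-fold lower number from compound 1 to compound 2 (0.59 log units; beyond the scatter). Compound 3 `Cc1cc(=O)n(-c2ccccc2OC(F)(F)F)nc1C(=O)Nc1ccc(Oc2ncnc3sccc23)c(F)c1` likewise returns only a limit in this assay, > 40000 nM. Compound 3 differs from compound 1 in its core by a group of 9 heavy atoms (6 carbon, 2 nitrogen, 1 sulfur; one five-membered aromatic ring with 1 hetero atom, one six-membered aromatic ring with 2 hetero atoms) in place of a group of 10 heavy atoms (7 carbon, 2 nitrogen, 1 oxygen; one six-membered aromatic ring with 1 hetero atom), on an oxygen on an aromatic ring, and this pair shows a step that the two limits leave unreadable from compound 1 to compound 3, a step that cannot be sized because the limit of > 40000 nM in this assay, at which 2 of the 3 values shown sit, covers both values. Compound 4 `Cc1cc(=O)n(-c2cccc(F)c2)nc1C(=O)Nc1ccc(Oc2ncnc3sccc23)c(F)c1` is not yet measured; it carries the same change on the core of compound 3 that compound 2 carries on the core of compound 1, namely (3-fluorophenyl in place of 2-(trifluoromethoxy)phenyl on an aromatic nitrogen), and the two places are described in the same words. An estimated step of an at least 2.6-fold lower number from compound 3 to compound 4 (0.42 log units; beyond the scatter) is therefore expected from compound 3 to compound 4, resting on an at least 3.9-fold lower number from compound 1 to compound 2 (0.59 log units; beyond the scatter). Compound 4 is expected to give about 15000 nM in this assay, most likely between 5000 nM and 40000 nM.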

Compound 4, half-maximal inhibitory concentration: 24500 nM
Beside the measured number, compound 4's estimate is 1.6-fold (0.21 log units) below it; low and high end bracket the measured number.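

Carried onto the core of compound 3, 3-fluorophenyl in place of 2-(trifluoromethoxy)phenyl gives an at least 1.6-fold lower number from compound 3 to compound 4 (0.21 log units; that floor lies within the scatter), so the lower number seen on the core of compound 1 is not contradicted, although this floor alone does not establish a step beyond the scatter. Set side by side in this assay, the two steps show the same direction at their floors but cannot be compared in size: the same change on two cores in this assay, an at least 3.9-fold lower number (0.59 log units; beyond the scatter) from compound 1 to compound 2 and an at least 1.6-fold lower number (0.21 log units; that floor lies within the scatter) from compound 3 to compound 4; the limit leaves it open whether they differ The exchange of the group on the oxygen gives a 2.4-fold higher number from compound 2 to compound 4 (0.38 log units; beyond the scatter) with 3-fluorophenyl in place, whereas the same exchange with 2-(trifluoromethoxy)phenyl cannot be read: the limit of > 40000 nM in this assay, at which 2 of the 4 values shown sit.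

The compounds shown leave open how large the change is on either core when the starting compound gives a number and not a limit. They also leave open how other groups on the aromatic nitrogen, such as an unsubstituted phenyl, a 4-fluorophenyl or a short alkyl chain, would read on these two cores.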